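The compounds below may be only part of what the source reports. "The series", "measured", "known", "first", "only" and "open" are said of these compounds alone.

Values in an assay on membranes from brain for displacement of a labelled ligand from Sigma non-opioid intracellular receptor 1 (Cavia porcellus), read by scintillation counting, with a stated time of 120 min; a higher number here means a weaker inhibitor, a lower number a stronger inhibitor:

Compound 1 `c1ccc(CN2CCC3(CC2)OCCc2cc(-c4ccccc4)sc23)cc1`: 2.4 nM
Compound 2 `c1ccc(CN2CCC3(CC2)OCCc2c(-c4ccccc4)csc23)cc1`: 1.6 nM
Compound 3 `COC1Cc2c(-c3ccccc3)csc2C2(CCN(Cc3ccccc3)CC2)O1`: 5.4 nM

Compound 2 has the lowest number of the three in this assay. Compound 1 lies within the scatter of it, so no order between those two is claimed. Compound 3 lies beyond the scatter: a 3.4-fold higher number from compound 2 to compound 3 (0.53 log units; beyond the scatter), a modest step.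

Compound 4 `c1ccc(CN2CCC3(CC2)OCCc2ccsc23)cc1` is not yet measured. It differs from compound 2 by hydrogen in place of phenyl on an aromatic carbon. Among the compounds with values here, no measured step covers this change: the only measured step concerns methoxy on a saturated ring carbon, and compounds 1 and 2, which carry the phenyl on different aromatic carbons, give values within the scatter of each other, so the phenyl's removal has no precedent here. With the phenyl gone the expectation is a weaker compound, a step of a 6.3-fold higher number from compound 2 to compound 4 (0.80 log units; beyond the scatter), although the size is uncertain. Compound 4 is therefore estimated at 10 nM in this assay, with a range from 2.5 nM to 40 nM.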

Compound 4, inhibition constant: 1 nM
Estimate against measurement, compound 4: 10-fold (1.00 log units) above; measured number outside the range, below it.
By their numbers in this assay, from the lowest: compounds 4, 2 and 1 (each within the scatter of the next, the first and the last beyond it); then compound 3.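

In this assay, the phenyl on this aromatic carbon of the five-membered aromatic ring with 1 sulfur can be replaced by hydrogen with no change beyond the scatter (a 1.6-fold lower number from compound 2 to compound 4 (0.20 log units; within the scatter)). Made against the compound carrying the phenyl on a different aromatic carbon, the same replacement gives a modest gain (a 2.4-fold lower number from compound 1 to compound 4 (0.38 log units; beyond the scatter)), so among these compounds a phenyl on this ring is not required for numbers this low. No measurement at hand accounts for either step.

Open, from the compounds shown here alone, is how a chlorine, an amine or a carboxylic acid on this aromatic carbon would read in this assay. Within the data shown here, also open is whether methoxy on the saturated ring carbon gives a similar step on the core without the phenyl, where the only reading so far is a 3.4-fold higher number from compound 2 to compound 3 (0.53 log units; beyond the scatter) with the phenyl in place.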